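A few compounds are considered here, and "the series" means these few. Any claim that something is new, unique, unknown or untested is made for them only; others in the source may bear on it.

All numbers below come from a functional assay on MCF7 cells (Homo sapiens) for cytotoxicity, read by sulforhodamine B assay; on this read-out higher numbers stand for an effect only at larger amounts of compound and lower numbers for an effect already at smaller amounts.

Compound 1 `C=C1CC[C@@H]2[C@](C)(COC(C)=O)[C@H](OC(C)=O)CC[C@@]2(C)[C@@H]1C/C=C1/C(=O)OC[C@H]1OC(C)=O`: 10 uM
Compound 2 `C=C1CC[C@@H]2[C@](C)(CO[Si](c3ccccc3)(c3ccccc3)C(C)(C)C)[C@H](OC(C)=O)CC[C@@]2(C)[C@@H]1C/C=C1/C(=O)OC[C@H]1OC(C)=O`: 45.7 uM
Compound 3 `C=C1CC[C@@H]2[C@](C)(COC(C)=O)[C@H](O)CC[C@@]2(C)[C@@H]1C/C=C1/C(=O)OC[C@H]1OC(C)=O`: 18.5 uM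

Compound 4 `C=C1CC[C@@H]2[C@](C)(CO[Si](c3ccccc3)(c3ccccc3)C(C)(C)C)[C@H](O)CC[C@@]2(C)[C@@H]1C/C=C1/C(=O)OC[C@H]1OC(C)=O` has not yet been measured in this assay.

Within the measured set, the change hydrogen in place of acetyl on an oxygen on a saturated carbon is seen once: it gives a 1.9-fold higher number from compound 1 to compound 3 (0.27 log units; within the scatter), a step that stays within the usual scatter, so no direction can be read from it.

How the core of compound 1 and the core of compound 2 differ is not broken down here. Of compound 2 the values only show that in this assay it gives 45.7 uM, the highest of the three numbers, beyond the scatter from both compound 3 and compound 1.

Compound 4 arises from compound 2 by hydrogen in place of acetyl on an oxygen on a saturated carbon. The place of this change is the same, word for word, as the place of the change from compound 1 to compound 3, so it is the same change, now applied to the core of compound 2 rather than the core of compound 1.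

Going by the values given here, for compound 4 the step from compound 2 is expected to be a 1.3-fold higher number from compound 2 to compound 4 (0.12 log units; within the scatter) in this assay, set beside the earlier step because a 1.9-fold higher number from compound 1 to compound 3 (0.27 log units; within the scatter) was the only measured precedent and lay within the scatter. Compound 4 is therefore estimated at 60 uM in this assay, with a range expected from 25 uM to 150 uM.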

Compound 4, concentration for half-maximal effect: 9.63 uM
Estimate against measurement, compound 4: 6.2-fold (0.79 log units) above, and the stated range ends above it.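

On the core of compound 2, acetoxy to hydroxy gives a 4.7-fold lower number from compound 2 to compound 4 (0.68 log units; beyond the scatter) in this assay. The same change does not read alike on the two cores: the same change on two cores in this assay, a 1.9-fold higher number (0.27 log units; within the scatter) from compound 1 to compound 3 and a 4.7-fold lower number (0.68 log units; beyond the scatter) from compound 2 to compound 4, 8.8-fold (0.94 log units) apart, beyond the scatter of two such steps. The size of this step therefore cannot be carried from one core to the other in this series, but with one pair per core, and with the step on the core of compound 1 lying within the scatter, this does not establish that the change acts in opposite directions, nor does it show which difference between the cores accounts for the gap.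

The compounds shown carry only acetyl or hydrogen on this oxygen, so it remains open how a longer acyl chain such as butanoyl, a methyl ether or an amine in place of the hydroxy would read on either core. Also open, from the compounds shown here alone, is whether the change on a further core would track the step seen on the core of compound 1 or the one seen on the core of compound 2.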